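Benzyl ether in place of the free phenol

The compounds below may be only part of what the source reports. "The series", "measured", "known", "first", "only" and "open" are said of these compounds alone.

Compound 1 `COc1ccc(/C=C/C(=O)c2cc3ccc(OCc4cccc(OC)c4)cc3oc2=O)cc1` is one of two members measured. In a functional assay on K562 cells (Homo sapiens) for cytotoxicity, read by MTT assay, with a stated time of 72 h (on this read-out lower numbers stand for stronger inhibition and higher numbers for weaker inhibition), compound 1 gives > 100000 nM, a limit of the assay rather than a number. Going by the values given here, compound 2 `COc1cccc(/C=C/C(=O)c2cc3cc(O)ccc3oc2=O)c1OC` gives 17300 nM in this assay and holds the only number. The other value, that of compound 1, is a limit. Compound 3 `COc1cccc(/C=C/C(=O)c2cc3cc(OCc4ccccc4)ccc3oc2=O)c1OC` is not yet measured; it differs from compound 2 by benzyl in place of hydrogen on an oxygen on an aromatic ring. Among the compounds with values here, no step between measured compounds is known. Compound 1 carries an ether on a comparable oxygen and sits at the limit of > 100000 nM in this assay, at which 1 of the 2 values shown sits. Against that background compound 3 is expected to weaken beyond the scatter, a step of a 2.6-fold higher number from compound 2 to compound 3 (0.42 log units; beyond the scatter). The estimate for compound 3 is 45000 nM, range 12000 nM to 150000 nM.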

Compound 3, half-maximal inhibitory concentration: 48900 nM
The estimate for compound 3 lay 1.1-fold (0.04 log units) below the measured number, and the stated range covers the measured number.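

Going by these compounds alone, at this position, replacing hydroxy with benzyloxy gives the first readable step in this assay: a 2.8-fold higher number from compound 2 to compound 3 (0.45 log units; beyond the scatter). The free hydroxy is therefore not needed for a measurable number in this pair, although the benzyl ether weakens the read-out. Compound 1 also carries an ether on a comparable oxygen but differs elsewhere, and it remains a limit rather than a number: the limit of > 100000 nM in this assay, at which 1 of the 3 values shown sits.

On these data alone, whether the step is specific to benzyl remains open. A methyl ether or a 2-aminoethyl ether on the same oxygen would test this against compound 2.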